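From 2-Fluorobenzyl to 3,4-Dichlorobenzyl

The compounds below may be only part of what the source reports. "The series", "measured", "known", "first", "only" and "open" are said of these compounds alone.

Of the compounds shown here, three have been tested so far in a functional assay on A-375 cells (Homo sapiens) for activation, with a stated time of 3 days; a higher number here means that more compound is needed for the effect, a lower number that less compound is needed. Here, compound 1 `O=C(Nc1ccc(-c2cscn2)cc1)C1CCN(Cc2ccc(F)c(F)c2)CC1` gives 19000 nM. Compound 2 `O=C(NC1CCCN(Cc2ccc(F)c(F)c2)C1)c1ccc(-c2cscn2)cc1` reads > 20000 nM, which is a limit of the assay and not a number. Compound 3 `O=C(Nc1ccc(-c2cscn2)cc1)C1CCCN(Cc2ccccc2F)C1` gives 7000 nM, the lowest of the two true numbers, and its gap to compound 1 lies beyond the usual scatter.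

Compound 4 `O=C(Nc1ccc(-c2cscn2)cc1)C1CCCN(Cc2ccc(Cl)c(Cl)c2)C1` follows from compound 3 through one structural change: 3,4-dichlorophenyl in place of 2-fluorophenyl on a saturated chain carbon bound to an amine nitrogen in a ring. Each of the two groups has one six-membered aromatic ring of carbon only, and neither carries a net charge.

Among the measured compounds shown here, no two tested compounds differ in one place alone, so no measured step shows what such a swap does. The expectation therefore starts from compound 3 at 7000 nM and assumes no clear shift beyond the scatter in this assay. The expected change is a 1.2-fold lower number from compound 3 to compound 4 (0.07 log units; within the scatter), a small step whose direction remains uncertain. For compound 4 the estimate is 6000 nM, with an expected range from 1500 nM to 19000 nM.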

Compound 4, half-maximal effective concentration: 3000 nM
For compound 4 the middle estimate is 2.0-fold (0.30 log units) above the measured one; the range from low to high includes it.
By their numbers in this assay, from the lowest: compound 4; then compound 3; then compound 1. At a limit, above all of these: compound 2.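

In this assay, the swap of 2-fluorophenyl for 3,4-dichlorophenyl gives a 2.3-fold lower number from compound 3 to compound 4 (0.37 log units; beyond the scatter), the first measured change in one place among these compounds. It shows that the group on the saturated chain carbon bound to the amine nitrogen in the ring can move the number beyond the usual scatter, even though both groups have one six-membered aromatic ring of carbon only and neither carries a net charge. Nothing measured here gives a reason for this step.

This single step changes the kind of halogen, the number of halogens and their places on the ring all at once, so it cannot tell which of these matters; a single-chlorine group such as 4-chlorophenyl would help to separate them. Also open, from the compounds shown here alone, is how the number would respond to a ring carrying an amine or a carboxylic acid, or to a longer chain in place of the saturated chain carbon that links the ring to the amine nitrogen.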